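Swapping a Ring on the Far Side of the Core

The source may hold more compounds than are shown below. What is called first, only, known or untested is meant among the compounds shown, and "the series" means these compounds.

Three measured compounds share a fused two-ring core that carries a chain with two amine groups. Compound 1 `CC(C)Cc1ccc2c(NCCCNCc3ccco3)ccnc2c1` in a physicochemical assay for acid dissociation, gives 9.47. Compound 3 `CC(C)CCc1ccc2c(NCCCNCc3ccco3)ccnc2c1` in this assay gives 9.47, and the step of no change at the digits printed from compound 1 to compound 3 (within the scatter) shows what that alteration did. Compound 2 `COc1ccc(F)cc1CNCCCNc1ccnc2cc(C3CCCCC3)ccc12` in this assay gives 9.47, which stands level with compounds 1 and 3 at the digits shown, within the scatter of the method.

Compound 4 `COc1ccc(F)cc1CNCCCNc1ccnc2cc(Oc3ccc(C(C)(C)C)cc3)ccc12` has not yet been measured. It differs from compound 2 in one place: 4-(tert-butyl)phenoxy in place of cyclohexyl on an aromatic carbon. Among the measured compounds shown here, the only measured step, from compound 1 to compound 3, altered a saturated chain attached to the aromatic part of the core and left the acid dissociation constant unchanged within the scatter. The alteration in compound 4 also sits on an aromatic carbon of the core rather than on the chain that carries the amine groups, and compound 2 itself sits level with compounds 1 and 3. The expected step of a number 0.02 log units lower from compound 2 to compound 4 (within the scatter) is therefore none beyond the scatter. Compound 4 is estimated at 9.45, with a likely range from 9.15 to 9.75.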

Compound 4, acid dissociation constant: 9.28
Compound 4: middle estimate off by 0.17 log units, on the high side; the measured number falls inside the stated range.
By their numbers in this assay, from the lowest: compounds 4, 1, 2 and 3 (each within the scatter of the next).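

In this assay, putting 4-(tert-butyl)phenoxy in place of cyclohexyl gives a number 0.19 log units lower from compound 2 to compound 4 (within the scatter) and so leaves the two numbers indistinguishable by this method. Among the compounds shown here, the only earlier step was a modest alteration of a saturated chain, whereas this one is much larger in size and kind: a group of 6 heavy atoms leaves and one with more heavy atoms enters, a non-aromatic ring of carbon gives way to an aromatic one, and an oxygen arrives that counts as a hydrogen-bond acceptor. Even a swap of this scale on this aromatic carbon, meta to a fused ring and para to a fused ring, produces no difference that can be separated from the scatter, although one pair of compounds is a single case and not a rule.

Still open, from the compounds shown here alone, is whether an amine or a carboxylic acid on this same aromatic carbon, or a longer chain between the two amine groups, would also leave the number within the scatter. Nothing available offers an explanation for this result.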